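This account rests on a few compounds, and the source may have more. Where it says the series, first, only, none or still open, it means among the compounds named here.

Of the compounds shown here, three have been read so far in a functional assay (strain AB) with Danio rerio as the target, read by microscopy, with a stated time of 1 h; on this read-out lower numbers stand for an effect already at smaller amounts and higher numbers for an effect only at larger amounts of compound. Compound 1 `CCC1CCc2c(sc(NC(=O)Nc3ccc(Cl)cc3)c2C(N)=O)C1` gives > 25000 nM, which is a limit and not a number. Compound 2 `CCN1CCc2c(sc(NC(=O)Nc3ccccc3)c2C(N)=O)C1` gives > 25000 nM, again a limit. Going by the values given here, compound 3 `CC(C)(C)OC(=O)CCCC[N+]1(C)CCc2c(sc(NC(=O)Nc3ccc(Cl)cc3)c2C(N)=O)C1` gives 140 nM, the only actual number.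

Compound 4 `CC(C)[N+]1(C)CCc2c(sc(NC(=O)Nc3ccc(Cl)cc3)c2C(N)=O)C1` has isopropyl in place of 4-(tert-butoxycarbonyl)butyl on an amine nitrogen in a ring. Among the compounds with values here, no measured pair isolates this change, so the expectation is loose and rests on compound 3 at 140 nM alone. In this assay the expected move is toward a higher number, beyond the scatter, with the estimated step of a 5.7-fold higher number from compound 3 to compound 4 (0.76 log units; beyond the scatter). The estimate for compound 4 is 800 nM, with an expected range from 100 nM to 8000 nM.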

Compound 4, half-maximal effective concentration: 960 nM
Estimate against measurement, compound 4: 1.2-fold (0.08 log units) below, within the range that was stated.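

Going by these compounds alone, on an amine nitrogen in a ring, isopropyl in place of 4-(tert-butoxycarbonyl)butyl gives the first readable step: a 6.9-fold higher number from compound 3 to compound 4 (0.84 log units; beyond the scatter). In this assay compound 4 still returns an actual number, so the long chain with its carbonyl is not required for a measurable effect, though the shorter group sits on the weaker side of this one pair. A single step is all the series yields so far: the limit of > 25000 nM in this assay, at which 2 of the 4 values shown sit.

Whether chain length or the tert-butyl ester accounts for the step stays open. A plain butyl or a free carboxylic acid on the same nitrogen would separate the two.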